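The compounds below may be only part of what the source reports. "The series", "measured", "known", "first", "only" and "open" are said of these compounds alone.

Measured compounds in an assay on HEK293 cells for binding affinity to 5-hydroxytryptamine receptor 7 (Homo sapiens), read by radioligand binding, tested at 1 uM; on this read-out higher numbers stand for more inhibition at the one concentration tested (going by the name of the read-out) and lower numbers for less inhibition:
compound 1 `Brc1ccc2ccn(CCN3CCCNCC3)c2c1` gives 77%
compound 2 `CC(C)N1CCCN(CCn2ccc3ccc(Br)cc32)CC1` gives 92%
compound 3 `CC(C)(C)CN1CCCN(CCn2ccc3ccc(Br)cc32)CC1` gives 70%

Compound 3 has the lowest of the three numbers. Its nearest neighbour is compound 1, and the step of a number 7 percentage points lower from compound 1 to compound 3 (within the scatter) lies within the scatter, so the two cannot be ordered. Its furthest neighbour is compound 2, with the step of a number 22 percentage points lower from compound 2 to compound 3 (beyond the scatter) lying beyond the scatter.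

The unmeasured compound 4 `Brc1ccc2ccn(CCN3CCCN(C4CCCC4)CC3)c2c1` differs from compound 3 in one place: cyclopentyl in place of neopentyl on an amine nitrogen in a ring.

Within the data shown here, no measured step exchanges neopentyl for cyclopentyl, so the expectation rests on the three substituents already seen on that ring nitrogen. Going from hydrogen to isopropyl, the step of a number 15 percentage points higher from compound 1 to compound 2 (beyond the scatter) was a modest rise; going from hydrogen to neopentyl, the step of a number 7 percentage points lower from compound 1 to compound 3 (within the scatter) stayed within the scatter; and going from isopropyl to neopentyl, the step of a number 22 percentage points lower from compound 2 to compound 3 (beyond the scatter) was a modest fall. Cyclopentyl carries the same count of five carbons as neopentyl but closes them into a ring, so the number for compound 4 is expected to sit between those of compound 3 and compound 2, closer to the latter. The expected step is a number 15 percentage points higher from compound 3 to compound 4 (beyond the scatter) in the direction of more inhibition. Compound 4 is thus estimated at 85% in this assay, with a range from 70% to 96%.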

Compound 4, a percentage reported as inhibition, at one concentration (the size of the read-out at that concentration, not a potency): 98%
Compound 4: the middle estimate sits 13 percentage points below what was measured; measured number above the stated range.
By their numbers in this assay, from the lowest: compounds 3 and 1 (each within the scatter of the next); then compounds 2 and 4 (each within the scatter of the next).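

In this assay, the carbon count of the group on the amine nitrogen in a ring does not settle the read-out: neopentyl and cyclopentyl hold the same count, yet closing those carbons into a five-membered ring gives a number 28 percentage points higher from compound 3 to compound 4 (beyond the scatter) at this position. Relative to the free ring nitrogen, cyclopentyl gives a number 21 percentage points higher from compound 1 to compound 4 (beyond the scatter) and so joins isopropyl as a group with a step beyond the scatter, while neopentyl has no such step, and the exchange of isopropyl for cyclopentyl gives a number 6 percentage points higher from compound 2 to compound 4 (within the scatter) so that these two groups cannot be ordered. Nothing available explains why the open neopentyl chain and the closed cyclopentyl ring part here.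

On these data alone, it remains open whether other carbon rings on this nitrogen, such as cyclopropyl or cyclohexyl, or a ring holding oxygen, such as tetrahydropyranyl, would read like cyclopentyl and isopropyl. As far as these compounds go, it is equally open whether an unbranched propyl or butyl chain would read like those groups or like neopentyl.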